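Swapping a pentyl for a phenyl on an amine nitrogen

The source may report more compounds than this note shows. Statements on the series, on what has been measured and on what is new or still open speak of the compounds shown alone.

Compound 1 `CCCOc1ccc(C(=O)Nc2cccc(Br)n2)cc1` is the simplest member of this small set. In an in vitro assay on HEK-tsA201 cells for antagonist activity at Neuronal acetylcholine receptor; alpha4/beta2 (Homo sapiens), read by fluorescence and calcium flux (on this read-out lower numbers stand for stronger inhibition and higher numbers for weaker inhibition), compound 1 gives 80700 nM. Compound 2 `CCCCCNc1cccc(NC(=O)c2ccc(OCCC)cc2)n1` carries a pentylamino group on the aromatic carbon where compound 1 carries a bromo. For compound 2 the value in this assay is only a limit, namely > 100000 nM, so no exact number is known for it. The step of an at least 1.2-fold higher number from compound 1 to compound 2 (0.09 log units; that floor lies within the scatter) therefore only sets a floor. This matters because the limit of > 100000 nM in this assay, at which 1 of the 2 values shown sits, shows that compound 2 sits at the edge of what this assay can measure.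

Compound 3 `CCCOc1ccc(C(=O)Nc2cccc(Nc3ccccc3)n2)cc1` differs from compound 2 in one place: phenyl in place of pentyl on a nitrogen on an aromatic ring. Within the data shown here, no measured step in this set covers such a change, and the single measured step only shows that replacing the bromo with a pentylamino group did not bring the number down. With nothing pointing to stronger inhibition, compound 3 is expected to remain near the limit, with an estimated step that the limit leaves unreadable from compound 2 to compound 3. Compound 3 is thus estimated at 150000 nM, within a range from 50000 nM to 500000 nM.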

Compound 3, half-maximal inhibitory concentration: > 100000 nM
Compound 3 was reported as a limit; the forecaster's own chance of this, stated with the estimate: 70%; the middle value does not contradict the limit.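

Placing a ring instead of a chain on this amine nitrogen, phenyl in place of pentyl, does not move the result off the limit of this assay: compound 3 gives > 100000 nM, which is a limit and not a number. The step from the pentylamino group to the anilino group cannot be read, as both ends of it are limits, so neither group can be ranked over the other. Replacing the bromo with anilino gives an at least 1.2-fold higher number from compound 1 to compound 3 (0.09 log units; that floor lies within the scatter), which again sets only a floor, and so two very different groups on the nitrogen at this aromatic carbon now show no sign of stronger inhibition, and the set is crowding against the top of the scale: the limit of > 100000 nM in this assay, at which 2 of the 3 values shown sit.

As far as these compounds go, it remains open how far past the limit compound 2 and compound 3 really lie, and whether they differ from each other at all. From the compounds shown here alone, it is also open whether a smaller group on this aromatic carbon, such as methylamino, or a chain ending in a carboxylic acid, would give a value that can be read in this assay.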